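A New Aryl Group on a Compound at the Limit

The compounds below may be only part of what the source reports. "The series", "measured", "known", "first", "only" and "open" are said of these compounds alone.

Compound 2 `Cn1ccc2c(Oc3ccc(NC(=O)c4nn(-c5ccc(Br)cc5)ccc4=O)cc3F)ccnc21` stands at the edge of what a functional assay on PC-3 cells (Homo sapiens) for cytotoxicity, read by MTT assay, with a stated time of 72 h (a lower number here means a stronger inhibitor, a higher number a weaker inhibitor), can report. In this assay compound 2 gives > 60000 nM, which is a limit and not a number. Compound 1 `O=C(Nc1ccc(Oc2ccnc3[nH]ccc23)c(F)c1)c1nn(-c2ccc(Cl)c(C(F)(F)F)c2)ccc1=O` gives a true reading, and in this assay compound 1 shows 5500 nM. Compound 1 carries the 4-chloro-3-(trifluoromethyl)phenyl group, on a core that is not the same as that of compound 2. Compound 3 `Cn1ccc2c(Oc3ccc(NC(=O)c4nn(-c5ccc(Cl)c(C(F)(F)F)c5)ccc4=O)cc3F)ccnc21` keeps the core of compound 2 and has 4-chloro-3-(trifluoromethyl)phenyl in place of 4-bromophenyl on an aromatic nitrogen. Going by the values given here, no measured pair isolates this change, so its size remains open. Among the compounds with values here, a clear step toward a stronger inhibitor is nevertheless expected in this assay, and the only guide is compound 1 at 5500 nM, which holds the same group. The expected change is an at least 6.0-fold lower number from compound 2 to compound 3 (0.77 log units; beyond the scatter). For compound 3 the estimated value is 10000 nM, with an expected range from 3000 nM to 40000 nM.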

Compound 3, half-maximal inhibitory concentration: 20900 nM
Compound 3: middle estimate off by 2.1-fold (0.32 log units), on the low side, and the stated range covers the measured number.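

On the aromatic nitrogen, 4-chloro-3-(trifluoromethyl)phenyl in place of 4-bromophenyl lifts the core of compound 2 off its limit and gives a true reading in this assay, with an at least 2.8-fold lower number from compound 2 to compound 3 (0.45 log units; beyond the scatter). Going by these compounds alone, the step has only a lower bound, and not a definite size, because compound 2 gives a limit and not a number: the limit of > 60000 nM in this assay, at which 1 of the 3 values shown sits. The result also makes the two cores comparable for the first time, since compound 1 and compound 3 carry the same aryl group and differ only by methyl in place of hydrogen on an aromatic nitrogen, with a 3.8-fold higher number from compound 1 to compound 3 (0.58 log units; beyond the scatter).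

The compounds shown do not separate the share of the chlorine from that of the trifluoromethyl group, since both enter together as the bromine leaves, and they do not show whether the difference between the two cores would hold with 4-bromophenyl as well. Going by these compounds, how a 4-methoxyphenyl group or a pyridine ring on the same nitrogen would read in this assay also stays open, as does any longer chain in place of the methyl on the core.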